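Swapping methoxy for chloro on an inactive core

The source may report more compounds than this note shows. Statements on the series, on what has been measured and on what is new or still open speak of the compounds shown alone.

This piece follows one small change to compound 1, whose structure is `COc1ccccc1C1CCc2nc[nH]c2C1`, and asks what it should do in a functional assay on CHO cells for agonist activity at Alpha-1B adrenergic receptor (Homo sapiens), read by FLIPR and calcium flux; a higher number here means that more compound is needed for the effect, a lower number that less compound is needed. Compound 1 gives only a limit there, > 10000 nM, which is the edge of what the assay can report and not a number. Compound 1 stands at the limit of > 10000 nM in this assay, at which 2 of the 3 values shown sit, so it cannot be placed more finely than that. Compound 2, with structure `c1ccc(C2CCc3nc[nH]c3C2)cc1`, has been run repeatedly and each time gives a limit, > 10000 nM; > 10000 nM; > 10000 nM (3 entries). Compound 3, with structure `c1ccc(C2CCc3nccn3C2)cc1`, gives a limit as well, > 10000 nM. No pair among these three has a step with a measured size, so all that can be said is that every value shown sits at the limit.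

The new compound is compound 4, structure `Clc1ccccc1C1CCc2nc[nH]c2C1`, and it differs from compound 1 by chloro in place of methoxy on an aromatic carbon. Going by the values given here, with no measured step of this kind to lean on, the expectation is that the change from compound 1 to compound 4 will not move the result beyond the scatter, and the step that the limit leaves unreadable from compound 1 to compound 4 is set accordingly as an estimate. Compound 4 is therefore expected to give about 20000 nM, within a range from 5000 nM to 100000 nM, most likely again as a limit rather than a number.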

Compound 4, half-maximal effective concentration: > 10000 nM
Compound 4: no number, only a limit (the forecaster's own chance of this, stated with the estimate: 85%); the middle value does not contradict the limit.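

Compound 1 and compound 4 each give only a limit in this assay, not a number, so the size of the step between them cannot be read. The compounds shown leave open how chloro and methoxy on the shared core compare, and whether any compound of this kind gives a measurable response in this assay at all.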